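Arylpiperazine series: fluoro for trifluoromethyl on the aryl ring

A few compounds are considered here, and "the series" means these few. Any claim that something is new, unique, unknown or untested is made for them only; others in the source may bear on it.

Compound 1 `CCCc1nc(-c2ccccc2)c(CNCCN2CCN(c3cccc(C(F)(F)F)c3)CC2)o1` is tested in an assay on HEK293 cells for inhibition of Voltage-dependent T-type calcium channel subunit alpha-1G (Homo sapiens), read by fluorescence, tested at 10 uM (a higher number here means more inhibition at the concentration tested (going by the name of the read-out), a lower number less inhibition), and gives 56.3%. This places it second highest of the three numbers in hand, though the spread is small: compound 2 `Cc1nc(-c2ccccc2)c(CNCCN2CCN(C(c3ccccc3)c3ccccc3)CC2)o1` gives 57.3%, within the scatter of compound 1, and compound 3 `CCCc1nc(-c2ccccc2)c(CNCCCN2CCN(c3ccc(C(F)(F)F)cc3)CC2)o1` gives 51.6%, also within the scatter. No order among the three can be read from these values.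

Compound 4 `CCCc1nc(-c2ccccc2)c(CNCCN2CCN(c3cccc(F)c3)CC2)o1` differs from compound 1 by fluoro in place of trifluoromethyl on an aromatic carbon. Among the measured compounds shown here, no measured pair shows this change, so its size is unknown from the data. Given that the three measured values sit close together, the expected step in this assay is small, leaning slightly downward, and not clearly beyond the scatter. The estimate for compound 4 is 50%, with a range from 30% to 70%. The expected step is a number 6.3 percentage points lower from compound 1 to compound 4 (within the scatter).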

Compound 4, a percentage reported as inhibition, at one concentration (the size of the read-out at that concentration, not a potency): 62.3%
Beside the measured number, compound 4's estimate is 12.3 percentage points below it, within the range that was stated.
By their numbers in this assay, from the lowest: compounds 3, 1, 2 and 4 (each within the scatter of the next, the first and the last beyond it).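

Fluoro in place of trifluoromethyl on this aromatic carbon gives the first pair in the series that differs in one place. In this assay the step reads a number 6 percentage points higher from compound 1 to compound 4 (within the scatter) and so shows no change that can be told from the scatter. At this position, 3-fluorophenyl therefore serves as well as 3-(trifluoromethyl)phenyl in this read-out, despite the loss of three heavy atoms.

Whether an amine or a carboxylic acid on the same aromatic carbon would keep the inhibition in this range stays open, and no data on hand speak to why the step came out as it did.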